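Shortening the Ether Chain: From Propyl to Vinyl

The source may hold more compounds than are shown below. What is called first, only, known or untested is meant among the compounds shown, and "the series" means these compounds.

The measured compounds in a functional assay on HepG2 cells (Homo sapiens) for cytotoxicity, read by MTT assay, with a stated time of 48 h; a higher number here means a weaker inhibitor, a lower number a stronger inhibitor:
compound 1, `CCCCCCOc1ccc2c(Cl)ccnc2c1`, gives 2420 nM
compound 2, `CC(C)COc1ccc2c(Cl)ccnc2c1`, gives 2250 nM
compound 3, `CCCCOc1ccc2c(Cl)ccnc2c1`, gives 2640 nM

Compound 3 carries the largest of the three numbers, yet it stands apart from neither neighbour: the step of a 1.1-fold higher number from compound 1 to compound 3 (0.04 log units; within the scatter) and the step of a 1.2-fold higher number from compound 2 to compound 3 (0.07 log units; within the scatter) both lie within the scatter, as does a 1.1-fold lower number from compound 1 to compound 2 (0.03 log units; within the scatter). Across these three compounds, reshaping the chain on the saturated chain carbon bound to an oxygen on the aromatic ring left the numbers unmoved.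

Compound 4, `C=CCOc1ccc2c(Cl)ccnc2c1`, is the next member of the series. The change is vinyl in place of propyl on a saturated chain carbon bound to an oxygen on an aromatic ring. The step from compound 2 to compound 3 is the one that bears most directly on it, since it also altered the group at the same place, and it stayed within the scatter. No step beyond the scatter is therefore expected in this assay: the estimated step is a 1.1-fold lower number from compound 3 to compound 4 (0.02 log units; within the scatter). Compound 4 is expected to give about 2500 nM, with a range from 1300 nM to 5000 nM.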

Compound 4, half-maximal inhibitory concentration: 2770 nM
The estimate for compound 4 lay 1.1-fold (0.04 log units) below the measured number; the measured number falls inside the stated range.
By their numbers in this assay, from the lowest: compounds 2, 1, 3 and 4 (each within the scatter of the next).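

In this assay the vinyl group brings the only double bond outside aromatic rings among these compounds, and the steps of a 1.0-fold higher number from compound 3 to compound 4 (0.02 log units; within the scatter) and a 1.2-fold higher number from compound 2 to compound 4 (0.09 log units; within the scatter) and a 1.1-fold higher number from compound 1 to compound 4 (0.06 log units; within the scatter) all stay within the scatter. The flat picture at this place, on a saturated chain carbon bound to an oxygen on an aromatic ring, therefore holds for an unsaturated chain as well as for the saturated ones, and none of the four compounds goes against it. (No measurement is at hand that would account for this).

From the compounds shown here alone, all four compounds carry plain hydrocarbon chains, so it remains open whether an amine or a carboxylic acid at the end of the chain, or a much longer chain, would move the number. The chlorine on the shared core is also the same throughout, so these compounds say nothing about replacing it.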